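The compounds below may be only part of what the source reports. "The series", "measured", "known", "first", "only" and "open" are said of these compounds alone.

Measured so far in a functional assay on the whole organism for antagonist activity, with Mus musculus as the target; a lower number here means that less compound is needed, a higher number that more compound is needed for the effect:
- Compound 1 `CCC(=O)N(c1ccc(F)cc1)C1CCCC1N(C)C`: 0.08 mg/kg
- Compound 2 `CCC(=O)N(c1ccc(C(=O)OC)cc1)C1CCCC1N(C)C`: > 50 mg/kg

Compound 2 gives > 50 mg/kg, which is a limit of the assay and not a number. All that is known is that it lies far out at the high end of this assay, with its true value unseen.

Compound 3 `CCC(=O)N(c1ccc(C(C)=O)cc1)C1CCCC1N(C)C` has methyl in place of methoxy on a carbonyl carbon, which turns methoxycarbonyl into acetyl (methyl in place of methoxy on a carbonyl carbon). Among the measured compounds shown here, no measured step makes this exact change. For the measured compounds named here, the nearest evidence is the one step at this same group, where methoxycarbonyl took the place of fluoro: an at least 620-fold higher number from compound 1 to compound 2 (2.79 log units; beyond the scatter). That step is large. Compound 3 keeps the carbonyl of compound 2 and has no fluoro, so it should stay much closer to compound 2 than to compound 1. A modest move towards a lower number is expected, or no visible move if compound 3 also ends at the limit. The expected change is an at least 2.0-fold lower number from compound 2 to compound 3 (0.30 log units; that floor lies within the scatter). For compound 3 the estimated value is 25 mg/kg, with an expected range of 3 mg/kg to 100 mg/kg.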

Compound 3, dose for half-maximal effect: 40 mg/kg
For compound 3 the middle estimate is 1.6-fold (0.20 log units) below the measured one; the measured number falls inside the stated range.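

In this assay compound 3 gives a true number, 40 mg/kg, so a carbonyl-bearing group at this aromatic carbon can now be sized against fluoro and not only bounded: a 500-fold higher number from compound 1 to compound 3 (2.70 log units; beyond the scatter). Acetyl has no methoxy, yet this step is still large, which shows that the high number at this place does not require the methoxy of methoxycarbonyl. Compound 2 stands at a limit and not at a number, so methyl in place of methoxy on the carbonyl carbon can only be stated as a floor, an at least 1.2-fold lower number from compound 2 to compound 3 (0.09 log units; that floor lies within the scatter), and that floor does not separate the two groups: the limit of > 50 mg/kg in this assay, at which 1 of the 3 values shown sits.

On these data alone, whether the large rise goes with the carbonyl itself or with losing fluoro remains open, as both groups compared with fluoro here carry a carbonyl. Chloro or methyl at the same aromatic carbon would test the first question, while a carboxylic acid or a primary amide on this carbon would show how far the number moves when the group on the carbonyl carbon changes again.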